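The compounds below may be only part of what the source reports. "The series", "measured", "known", "first", "only" and "open" are said of these compounds alone.

Measured so far:
- Compound 1 `O=C(Nc1ccc(-c2ccc(C(=O)Nc3ccc(C(=O)O)c4ccccc34)cc2)cc1)c1ccc([N+](=O)[O-])cc1`: 17000 nM
- Compound 2 `COC(=O)c1ccc(C(=O)Nc2ccc(-c3ccc(C(=O)Nc4cccc5cccc(S(=O)(=O)O)c45)cc3)cc2)cc1`: 240000 nM

In a physicochemical assay for solubility (on this read-out lower numbers stand for lower solubility and higher numbers for higher solubility), compound 2 gives the higher of the two numbers, 240000 nM, well beyond the scatter from compound 1. Compound 3 `O=C(Nc1ccc(-c2ccc(C(=O)Nc3cccc4cccc(S(=O)(=O)O)c34)cc2)cc1)c1ccc([N+](=O)[O-])cc1` differs from compound 2 in one place: nitro in place of methoxycarbonyl on an aromatic carbon. Compound 1 also carries 4-nitrophenyl but differs elsewhere too, so its gap says little about this change alone. The expected change, a 1.6-fold lower number from compound 2 to compound 3 (0.20 log units; within the scatter), is slightly downward and within the scatter. The estimate for compound 3 is 150000 nM, with an expected range from 50000 nM to 400000 nM.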

Compound 3, solubility: 7000 nM
Beside the measured number, compound 3's estimate is 21-fold (1.33 log units) above it; measured number below the stated range.
By their numbers in this assay, from the lowest: compound 3; then compound 1; then compound 2.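

In this assay, putting nitro in place of methoxycarbonyl gives a 34-fold lower number from compound 2 to compound 3 (1.54 log units; beyond the scatter), a large step beyond the scatter. This position, para to a large group, therefore matters to the read-out, even though the donor and acceptor counts of the two groups are the same. Nothing shown here explains the size of this step.

From the compounds shown here alone, only these two groups can be compared at this position, so it remains open how other groups would behave there. An amine or a nitrile on this carbon would show whether the lower number is particular to nitro.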